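This account rests on a few compounds, and the source may have more. Where it says the series, first, only, none or still open, it means among the compounds named here.

Working notes on the selenium series.

Two compounds carry measurements in a functional assay on HT-29 cells (Homo sapiens) for cytotoxicity, read by MTT assay, with a stated time of 72 h; a higher number here means a weaker inhibitor of growth, a lower number a stronger inhibitor of growth. Compound 1 `C[Se]/C(=N\C(=O)c1cccs1)NC(=O)c1cccs1` is the reference point: in this assay compound 1 gives 0.34 nM. Compound 2 `O=C(/N=C(/NC(=O)c1cc(-c2ccccc2)nc2ccccc12)[Se]Cc1ccccc1)c1cc(-c2ccccc2)nc2ccccc12` stands at the other end; in this assay compound 2 gives 6070 nM, the highest of the two numbers, and the gap to compound 1 is far beyond the scatter. Within the data shown here, these two compounds differ in more than one place, so no single step between them can be read off; the two values only show that a methyl on selenium with thiophene carbonyls sits very low and a benzyl on selenium with phenylquinoline carbonyls sits very high.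

Compound 3 `C[Se]/C(=N\C(=O)c1cc(-c2ccccc2)nc2ccccc12)NC(=O)c1cc(-c2ccccc2)nc2ccccc12` is not yet measured. It keeps the carbonyl parts of compound 2 and changes only the selenium substituent: hydrogen in place of phenyl on a saturated chain carbon bound to a selenium atom. This brings the selenium substituent back to that of compound 1.

Because compound 1 with the same methyl on selenium gives 0.34 nM, a move toward lower numbers beyond the scatter is expected for compound 3, though the carbonyl parts of compound 2 are retained and the size of the step is uncertain. The step from compound 2 to compound 3 is estimated as a 12-fold lower number from compound 2 to compound 3 (1.08 log units; beyond the scatter). For compound 3 the expected value is 500 nM, within a range from 20 nM to 6000 nM.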

Compound 3, concentration for 50% growth inhibition: 460 nM
For compound 3 the middle estimate is 1.1-fold (0.04 log units) above the measured one; low and high end bracket the measured number.
By their numbers in this assay, from the lowest: compound 1; then compound 3; then compound 2.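

The step shows that, with the carbonyl parts of compound 2 held fixed, the selenium substituent alone moves the number beyond the scatter: hydrogen in place of phenyl on a saturated chain carbon bound to a selenium atom, or benzyl to methyl in the wider cut, gives a 13-fold lower number from compound 2 to compound 3 (1.12 log units; beyond the scatter) in this assay. The first two compounds could not separate the selenium substituent from the carbonyl parts, but here the methyl on selenium does not by itself bring the number to that of compound 1, as compound 3 gives 460 nM and compound 1 gives 0.34 nM, and these two differ in more than one place, so no single step can be read between them. Nothing on hand bears on why the benzyl to methyl change acts as it does.

The compounds shown leave open whether the number moves steadily with chain size on selenium, since an ethyl or a longer chain there would fall between methyl and benzyl. They also leave open how a carboxylic acid or an amine at the end of that chain would read, and whether benzyl to methyl gives a step of similar size on the carbonyl parts of compound 1.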